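A few compounds are considered here, and "the series" means these few. Any claim that something is new, unique, unknown or untested is made for them only; others in the source may bear on it.

Among the compounds with values here, in a functional assay on HepG2 cells (Homo sapiens) for inhibition, read by MTT assay, with a stated time of 48 h (on this read-out lower numbers stand for stronger inhibition and higher numbers for weaker inhibition), compound 2 `COc1cc(-c2nnc(SCC(=O)c3ccccc3)n2-c2ccc(N(C)C)cc2)cc(OC)c1OC` gives 18900 nM, the only true number so far. Compound 1 `COc1cc(-c2nnc(SC)n2-c2ccc(N(C)C)cc2)cc(OC)c1OC` gives > 60000 nM, which is a limit of the assay. Within the data shown here, the one measured step is an at least 3.1-fold lower number from compound 1 to compound 2 (0.50 log units; beyond the scatter), with benzoyl in place of hydrogen on a saturated chain carbon bound to a sulfur. Its size is only a bound because of the limit of > 60000 nM in this assay, at which 1 of the 2 values shown sits.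

Compound 3 `COc1ccc(C(=O)CSc2nnc(-c3cc(OC)c(OC)c(OC)c3)n2-c2ccc(N(C)C)cc2)cc1O` carries 3-hydroxy-4-methoxyphenyl in place of phenyl on a carbonyl carbon, that is, 3-hydroxy-4-methoxyphenyl in place of phenyl on a carbonyl carbon. Among the measured compounds shown here, no measured step changes this group directly, so the evidence is thin. The closest guide is an at least 3.1-fold lower number from compound 1 to compound 2 (0.50 log units; beyond the scatter), which altered the same side chain and lowered the number. A further modest lowering is therefore expected in this assay, with the estimated step being a 3.2-fold lower number from compound 2 to compound 3 (0.50 log units; beyond the scatter), although a result within the scatter remains possible. For compound 3 the estimate is 6000 nM, with an expected range of 800 nM to 25000 nM.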

Compound 3, half-maximal inhibitory concentration: > 100000 nM
Compound 3: no number, only a limit; the forecaster's own chance of this, stated with the estimate: 10%; at least 16-fold (1.22 log units) between middle value and limit.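

On the carbonyl carbon, 3-hydroxy-4-methoxyphenyl in place of phenyl gives in this assay an at least 5.2-fold higher number from compound 2 to compound 3 (0.72 log units; beyond the scatter), so the outcome at this position depends on the group carried by the carbonyl and not only on the presence of the side chain. Within the data shown here, the lower number seen with benzoyl therefore does not extend to this substituted group, and compound 2 remains the only true number. The size of this step is only a bound because of a limit: the limit of > 100000 nM in this assay, at which 1 of the 3 values shown sits.

The step linking the other two compounds cannot be read, as both of its ends are limits. Still open, from the compounds shown here alone, is whether the change tracks the hydroxy group, the methoxy group or the pair, which 3-hydroxyphenyl and 4-methoxyphenyl on the same carbonyl carbon would separate.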